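The source may hold more compounds than are shown below. What is called first, only, known or untested is meant among the compounds shown, and "the series" means these compounds.

Going by the values given here, in a functional assay on B16-F10 cells (Mus musculus) for antiproliferative activity, read by MTT assay, with a stated time of 48 h (on this read-out higher numbers stand for weaker inhibition and lower numbers for stronger inhibition), two compounds built on the same core have numbers so far. Compound 1 `Brc1ccc(NCc2cn(-c3ccccc3)nc2-c2ccc(Br)cc2)cc1` gives 5270 nM, and compound 2 `Fc1ccc(NCc2cn(-c3ccccc3)nc2-c2ccc(Br)cc2)cc1` gives 4180 nM. These two values sit within the usual scatter of each other, so the data do not separate them, and compound 2 stands level with compound 1.

Compound 3 `Clc1ccc(NCc2cn(-c3ccccc3)nc2-c2ccc(Br)cc2)cc1` has not yet been measured. It carries chloro in place of fluoro on an aromatic carbon, para to a large group, turning the 4-fluorophenyl into a 4-chlorophenyl: chloro in place of fluoro on an aromatic carbon. The rest of the molecule stays the same.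

Among the compounds with values here, the only measured change at this place is a 1.3-fold lower number from compound 1 to compound 2 (0.10 log units; within the scatter), a swap of bromo for fluoro that stayed within the scatter. With that single step as the guide, no change beyond the scatter is expected, and the estimated step is a 1.1-fold higher number from compound 2 to compound 3 (0.05 log units; within the scatter). One step is thin evidence, so the expected range is kept wide. For compound 3 the estimated value is 4700 nM, with an expected range of 2500 nM to 8500 nM.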

Compound 3, half-maximal inhibitory concentration: 4290 nM
Estimate against measurement, compound 3: 1.1-fold (0.04 log units) above, within the range that was stated.
By their numbers in this assay, from the lowest: compounds 2, 3 and 1 (each within the scatter of the next).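

With chloro now at this place, three halogens can be compared on the same aromatic carbon. In this assay the swap of fluoro for chloro gives a 1.0-fold higher number from compound 2 to compound 3 (0.01 log units; within the scatter) and the swap of bromo for chloro gives a 1.2-fold lower number from compound 1 to compound 3 (0.09 log units; within the scatter) in this series. The earlier pair showed only that fluoro and bromo could not be told apart, whereas all three halogens on this aromatic carbon, para to a large group, now read alike, so this assay draws no distinction among them, and nothing available explains that sameness.

Going by these compounds alone, every group tested at this place so far is a single halogen atom, so it remains open whether a different kind of group there, such as a methoxy, an amine or a carboxylic acid, would move the number beyond the scatter. The compounds shown also leave open how much the bromo elsewhere on the shared core or the unsubstituted phenyl contributes, as both stay the same throughout this set.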